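A few compounds are considered here, and "the series" means these few. Any claim that something is new, unique, unknown or untested is made for them only; others in the source may bear on it.

Working notes on the series. In a functional assay on MV4-11 cells (Homo sapiens) for inhibition, read by resazurin assay, with a stated time of 72 h (a higher number here means a weaker inhibitor of growth, a lower number a stronger inhibitor of growth), compound 1 (`COc1ccc(Nc2nccc(-c3sc(OC)nc3C)n2)c(OC)c1`) gives 1400 nM, compound 2 (`COc1ccc(Nc2nccc(-c3sc(SCc4cccnc4)nc3C)n2)c(OC)c1`) gives 270 nM and compound 3 (`CCCSc1nc(C)c(-c2ccnc(Nc3ccc(OC)cc3OC)n2)s1`) gives 2240 nM. Two steps fix the place of the propylsulfanyl compound: a 1.6-fold higher number from compound 1 to compound 3 (0.20 log units; within the scatter), with no separation, and an 8.3-fold higher number from compound 2 to compound 3 (0.92 log units; beyond the scatter), a clear separation. It therefore stands level with the methoxy compound and apart from the pyridine-bearing one.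

Compound 4 (`CCSc1nc(C)c(-c2ccnc(Nc3ccc(OC)cc3OC)n2)s1`) differs from compound 3 by hydrogen in place of methyl on a saturated chain carbon, two bonds along the chain from a sulfur, so propylsulfanyl becomes ethylsulfanyl.

For the measured compounds named here, no measured step changes the chain length alone. One larger change is a 5.2-fold lower number from compound 1 to compound 2 (0.71 log units; beyond the scatter). The other is an 8.3-fold higher number from compound 2 to compound 3 (0.92 log units; beyond the scatter). Both involve the pyridin-3-yl group, which neither compound 3 nor compound 4 carries, so they say little here. The closest guide is the replacement of methoxy by propylsulfanyl, a 1.6-fold higher number from compound 1 to compound 3 (0.20 log units; within the scatter), which stays within the scatter. No step beyond the scatter is therefore expected in this assay, and no firm direction. The expected change is a 1.2-fold lower number from compound 3 to compound 4 (0.09 log units; within the scatter). Compound 4 is estimated at 1800 nM, with an expected range of 900 nM to 3600 nM.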

Compound 4, concentration for 50% growth inhibition: 32400 nM
For compound 4 the middle estimate is 18-fold (1.26 log units) below the measured one; the whole stated range lies below it.
By their numbers in this assay, from the lowest: compound 2; then compounds 1 and 3 (each within the scatter of the next); then compound 4.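

In this assay, the end of the sulfur-bound chain proves to be a sensitive place: hydrogen in place of methyl, turning propylsulfanyl into ethylsulfanyl, gives a 14-fold higher number from compound 3 to compound 4 (1.16 log units; beyond the scatter), a large step from the loss of a single carbon. The sulfur link alone therefore does not set the level, since the exchange of methoxy for ethylsulfanyl gives a 23-fold higher number from compound 1 to compound 4 (1.36 log units; beyond the scatter), whereas the propylsulfanyl exchange stayed within the scatter, and the distance from the pyridine-bearing chain also grows to a 120-fold higher number from compound 2 to compound 4 (2.08 log units; beyond the scatter). Nothing shown here accounts for the loss seen on this small change.

From the compounds shown here alone, the chain series holds only propylsulfanyl and ethylsulfanyl, so it remains open whether ethylsulfanyl is an isolated low point or part of a trend with chain length, which methylsulfanyl and butylsulfanyl compounds would help to settle. Going by these compounds, it also remains open whether the stronger growth inhibition of compound 2 needs the pyridine nitrogen, a question that a benzylsulfanyl group, with phenyl in place of pyridin-3-yl, would address.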